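A Fluorine Step Repeated on a Second Core

A few compounds are considered here, and "the series" means these few. Any claim that something is new, unique, unknown or untested is made for them only; others in the source may bear on it.

Compound 1 `N/C(=N\NC(=S)N1CCCCCC1)c1ccccn1` gives 90% in a functional assay on A-375 cells (Homo sapiens) for cytotoxicity, read by MTT assay, with a stated time of 72 h, tested at 30 uM; a lower number here means less inhibition of growth, a higher number more inhibition of growth at the concentration tested. Compound 2 `N/C(=N\NC(=S)N1CCOCC1)c1ccccn1` gives 15% in this assay, and compound 3 `N/C(=N\NC(=S)N1CCOCC1)c1ccc(F)cn1` gives 85.9%. The difference between the cores of compound 1 and compound 2 is not broken down here. From compound 2 to compound 3 the change is fluoro in place of hydrogen on an aromatic carbon, and the step is a number 70.9 percentage points higher from compound 2 to compound 3 (beyond the scatter). The same change, (fluoro in place of hydrogen on an aromatic carbon), leads from compound 1 to compound 4 `N/C(=N\NC(=S)N1CCCCCC1)c1ccc(F)cn1`. Compound 3 lies within the scatter of compound 1, while compound 2 lies far below both. Because compound 1 already gives 90%, little room remains, so the expected step from it is a number 1 percentage points higher from compound 1 to compound 4 (within the scatter), far smaller than the earlier one. Compound 4 is expected to give 91%, between 78% and 98%.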

Compound 4, percent growth inhibition at one concentration: 80%
Compound 4: middle estimate off by 11 percentage points, on the high side; low and high end bracket the measured number.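

Among the compounds shown here, the new step is a number 10 percentage points lower from compound 1 to compound 4 (within the scatter), so on the core of compound 1 the fluoro for hydrogen change gives no step that stands out from the scatter. The change therefore does not carry over in size from one core to the other in this assay: the same change on two cores in this assay, a number 70.9 percentage points higher (beyond the scatter) from compound 2 to compound 3 and a number 10 percentage points lower (within the scatter) from compound 1 to compound 4, 80.9 percentage points apart, beyond the scatter of two such steps

This shows that the effect of the change depends on the core in this small set, but with one pair on each core it does not show why, nor how a further core would respond. The compounds shown leave open what a chloro or a methoxy group in place of the fluoro would give on either core.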